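The source may hold more compounds than are shown below. What is called first, only, known or untested is meant among the compounds shown, and "the series" means these compounds.

Measured so far in a functional assay on the whole organism for inhibition, with Mus musculus as the target, at a dose of 32 mg/kg by the oral route; a lower number here means less inhibition, a higher number more inhibition at the dose given (going by the name of the read-out):
compound 1, `CCSc1ccc2c(c1)c(O)c(C(=O)N(C)c1ccccc1)c(=O)n2C`, gives 100%
compound 2, `CSc1ccc2c(c1)c(Cl)c(C(=O)N(C)c1ccccc1)c(=O)n2C`, gives -1%

Compound 2 stands lowest of the two numbers in this assay, and its nearest neighbour is compound 1, which lies higher by a gap well beyond the usual scatter. Compounds 1 and 2 differ from each other in two places, so what their values show cannot be assigned to either change alone; only the two numbers themselves are known.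

Compound 3, `CNc1c(C(=O)N(C)c2ccccc2)c(=O)n(C)c2ccc(SC)cc12`, has not yet been measured in this assay. It differs from compound 2 in one place: methylamino in place of chloro on an aromatic carbon. For the measured compounds named here, a group with one hydrogen-bond donor and one hydrogen-bond acceptor enters where chloro stood, and compound 1, the only compound with a high value, also carries a donor group on the same carbon of the shared core.

Going by the values given here, on that slim basis, the step in this assay from compound 2 to compound 3 is expected to be a number 46 percentage points higher from compound 2 to compound 3 (beyond the scatter), upward and beyond the scatter, though with wide uncertainty since no single-change step is available. Compound 3 is therefore estimated at 45%, within a range from 5% to 90%.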

Compound 3, a percentage reported as inhibition, in the whole organism at one dose (the size of the read-out at that dose, not a potency): 83%
Estimate against measurement, compound 3: 38 percentage points below; the measured number falls inside the stated range.
By their numbers in this assay, from the lowest: compound 2; then compound 3; then compound 1.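

In this assay, putting methylamino in place of chloro on this aromatic carbon, opposite the ring nitrogen, gives a number 84 percentage points higher from compound 2 to compound 3 (beyond the scatter). For the compounds shown here, this is the first change in one place that can be read, and it shows that with everything else in the structure held the same, the group on this carbon alone can separate a low number from a high one at this oral dose. Nothing at hand says which feature of the exchange accounts for the size of the step, and no measurement beyond the read-out itself bears on it.

The exchange swaps chloro for a group that differs in its atoms, its size and its count of hydrogen-bond donors and acceptors, so these differences remain tied together, and the compounds shown cannot say how a plain amino group, a dimethylamino group, a methoxy group or a longer chain on the nitrogen would fare on the same carbon. The ethylthio group and the hydroxy group of compound 1 also remain unassigned, since that compound differs in two places from each of the others.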